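The source may hold more compounds than are shown below. What is called first, only, known or untested is meant among the compounds shown, and "the series" means these compounds.

Measured compounds in a functional assay on A2780 cells (Homo sapiens) for antiproliferative activity, read by sulforhodamine B assay, with a stated time of 48 h; on this read-out higher numbers stand for weaker inhibition and lower numbers for stronger inhibition:
- compound 1, `COc1ccc(/C=C/C(=O)c2ccccc2-c2ccc(F)cc2)cc1`, gives 170 nM
- compound 2, `CN(C)c1ccc(/C=C/C(=O)c2ccccc2-c2ccc(F)cc2)cc1`, gives 94 nM

Compound 1 holds the higher of the two numbers; its nearest neighbour is compound 2, and the step of a 1.8-fold lower number from compound 1 to compound 2 (0.26 log units; within the scatter) does not leave the scatter, so the two values cannot be ordered.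

Compound 3, `COc1ccc(/C=C/C(=O)c2ccccc2-c2cccc(F)c2)cc1`, is not yet measured. Against compound 1 the change is 3-fluorophenyl in place of 4-fluorophenyl on an aromatic carbon. Among the measured compounds shown here, the one measured step, from compound 1 to compound 2, alters a substituent on the other aromatic ring and says nothing about moving the fluorine on the ring that enters here. For the measured compounds named here, no measured pair speaks to the fluorophenyl placement at all. With no evidence for movement in either direction, compound 3 is expected to give a step within the scatter, no change at the digits printed from compound 1 to compound 3 (within the scatter). The estimate for compound 3 in this assay is 170 nM, expected to lie between 70 nM and 420 nM.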

Compound 3, half-maximal inhibitory concentration: 160 nM
Compound 3: middle estimate off by 1.1-fold (0.03 log units), on the high side; low and high end bracket the measured number.
By their numbers in this assay, from the lowest: compounds 2, 3 and 1 (each within the scatter of the next).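

In this assay, 3-fluorophenyl in place of 4-fluorophenyl on an aromatic carbon, ortho to a large group, gives a 1.1-fold lower number from compound 1 to compound 3 (0.03 log units; within the scatter), so the two fluorine placements cannot be told apart on this read-out. Compound 1 and compound 2 share the 4-fluorophenyl, so this pair is the only one that speaks to where the fluorine sits on that ring. No further data bear on the reason for this result.

On these data alone, only fluorine has been varied on this ring, and only between these two placements, so it remains open how the series would respond to an unsubstituted phenyl or to a nitrile, an amine or a carboxylic acid on that ring. Also open, as far as these compounds go, is whether the dimethylamino group of compound 2 would read the same alongside 3-fluorophenyl.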